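Drawing the Double Bond Configuration in Compound 3

The compounds below may be only part of what the source reports. "The series", "measured", "known", "first", "only" and "open" are said of these compounds alone.

Compound 1 `C/C(=N/NC(=S)Nc1ccc(Cl)cc1)c1ccccn1` gives 5.9 nM in a functional assay on T98G cells (Homo sapiens) for cytotoxicity, read by MTT assay, with a stated time of 48 h; on this read-out lower numbers stand for stronger inhibition and higher numbers for weaker inhibition. Compound 2 `CC(=NNC(=S)Nc1ccc(I)cc1)c1ccccn1` gives 64 nM in this assay, the highest of the two numbers seen so far, with compound 1 the nearest at a lower number that lies beyond the scatter. Compound 3 `C/C(=N/NC(=S)Nc1ccc(I)cc1)c1ccccn1` differs from compound 2 only in the two compounds have the same atoms and bonds; at least one stereo element is drawn with a configuration in one of them and without one in the other: 1 of 1 stereo elements differ; a double bond is drawn without a configuration in compound 2 and Z in compound 3. Going by the values given here, no step between measured compounds is available for this kind of change, so the step of no change at the digits printed from compound 2 to compound 3 (within the scatter) is expected to stay within the scatter, in no particular direction. Compound 3 is therefore estimated at 64 nM in this assay, between 25 nM and 160 nM.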

Compound 3, half-maximal inhibitory concentration: 64 nM
The estimate for compound 3 equals the measured number at the digits printed; the range from low to high includes it.
By their numbers in this assay, from the lowest: compound 1; then compounds 2 and 3 (each within the scatter of the next).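

Drawing the double bond as Z leaves the reading in this assay untouched, with no change at the digits printed from compound 2 to compound 3 (within the scatter), so this double bond's drawn configuration makes no visible difference here. The only thing that separates these two entries is this: the fact that one of compounds 2 and 3 is drawn with a defined configuration and the other without, at the place where they differ With both halogen compounds now drawn alike, iodo in place of chloro gives an 11-fold higher number from compound 1 to compound 3 (1.04 log units; beyond the scatter), so the gap does not depend on how the double bond is drawn.

Still open, on these data alone, is how a bromo group or an amine at this aromatic carbon would read. As far as these compounds go, the reading of the E form also remains open.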